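From 2,4-Dichlorophenyl to 2,4-Difluorophenyl on a Shared Core

The compounds below may be only part of what the source reports. "The series", "measured", "known", "first", "only" and "open" are said of these compounds alone.

Of the compounds shown here, three with a shared core have been measured in a functional assay on OVCAR-8 cells (Homo sapiens); a higher number here means a weaker inhibitor of growth, a lower number a stronger inhibitor of growth. Compound 1 (`O=S(=O)(/C=C/c1ccc(F)cc1)Cc1ccc(Nc2ncnc3ccccc23)cc1`) gives 2000 nM, compound 2 (`O=S(=O)(/C=C/c1ccc(Cl)c(Cl)c1)Cc1ccc(Nc2ncnc3ccccc23)cc1`) gives 14000 nM and compound 3 (`O=S(=O)(/C=C/c1ccc(Cl)cc1Cl)Cc1ccc(Nc2ncnc3ccccc23)cc1`) gives 4000 nM. Compound 3 therefore stands level with compound 1 within the scatter and well under compound 2. Compound 4 (`O=S(=O)(/C=C/c1ccc(F)cc1F)Cc1ccc(Nc2ncnc3ccccc23)cc1`) differs from compound 3 in a single place: 2,4-difluorophenyl in place of 2,4-dichlorophenyl on a double-bonded chain carbon bound to a double-bonded chain carbon.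

Within the data shown here, no measured step makes this exact exchange, so the evidence is indirect. Among the measured compounds shown here, the closest comparison is a 2.0-fold higher number from compound 1 to compound 3 (0.30 log units; within the scatter), which links the 2,4-dichlorophenyl group to the only measured compound bearing fluorine and stays within the scatter. Moving the chlorines gave a 3.5-fold lower number from compound 2 to compound 3 (0.54 log units; beyond the scatter), and the 3,4-dichlorophenyl group gave a 7.0-fold higher number from compound 1 to compound 2 (0.85 log units; beyond the scatter), so the substitution pattern can matter in this assay. Here the pattern stays the same, so only a small shift towards compound 1 is expected. The expected change is a 1.6-fold lower number from compound 3 to compound 4 (0.20 log units; within the scatter). Compound 4 is estimated at 2500 nM, with an expected range of 1000 nM to 6000 nM.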

Compound 4, concentration for 50% growth inhibition: > 100000 nM
Compound 4 gave a limit, no number (the forecaster's own chance of this, stated with the estimate: 2%); middle value at least 40-fold (1.60 log units) away from the limit.
By their numbers in this assay, from the lowest: compounds 1 and 3 (each within the scatter of the next); then compound 2. At a limit, above all of these: compound 4.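

In this assay, compound 4 carries a limit of the assay and not a number: the limit of > 100000 nM in this assay, at which 1 of the 4 values shown sits. Among these compounds, the aryl group on this double-bonded chain carbon proves far less forgiving than the earlier compounds suggested, since exchanging the two chlorines of 2,4-dichlorophenyl for the two fluorines of 2,4-difluorophenyl gives an at least 25-fold higher number from compound 3 to compound 4 (1.39 log units; beyond the scatter), and the printed step exceeds the change seen on moving the chlorines, a 3.5-fold lower number from compound 2 to compound 3 (0.54 log units; beyond the scatter). Even the 3,4-dichlorophenyl compound is left behind, with an at least 7.1-fold higher number from compound 2 to compound 4 (0.85 log units; beyond the scatter), and a single fluoro in place of hydrogen on an aromatic carbon gives an at least 50-fold higher number from compound 1 to compound 4 (1.69 log units; beyond the scatter).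

The compounds shown leave open whether a plain phenyl group or a methoxyphenyl group at this place would read like compound 1 or like compound 4. As far as these compounds go, how far compound 4 lies past its limit also remains unknown.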